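Swapping a fluorinated benzamide for a chlorinated one

The compounds below may be only part of what the source reports. "The series", "measured", "known", "first", "only" and "open" are said of these compounds alone.

Compound 3 `Cn1cnc(S(=O)(=O)N2CC3CCC(NC(=O)c4cccc(F)c4)C3C2)c1` carries a 3-fluorophenyl group on the amide carbonyl. In an assay on isolated protein for inhibition of sodium- and chloride-dependent glycine transporter 1 (Homo sapiens) (on this read-out higher numbers stand for weaker inhibition and lower numbers for stronger inhibition), compound 3 gives > 10000000 nM, which is a limit of the assay rather than a number (the limit of > 10000000 nM in this assay, at which 1 of the 3 values shown sits). Its relatives are compound 1 `Cn1cnc(S(=O)(=O)N2CC3CCC(NC(=O)c4ccccc4C(F)(F)F)C3C2)c1` with 112000 nM and compound 2 `Cn1cnc(S(=O)(=O)N2CC3CCC(NC(=O)c4ccccc4F)C3C2)c1` with 1820000 nM. Every measured step weakened inhibition: a 16-fold higher number from compound 1 to compound 2 (1.21 log units; beyond the scatter), an at least 5.4-fold higher number from compound 2 to compound 3 (0.73 log units; beyond the scatter) and an at least 89-fold higher number from compound 1 to compound 3 (1.95 log units; beyond the scatter). Compound 4 `Cn1cnc(S(=O)(=O)N2CC3CCC(NC(=O)c4ccc(Cl)cc4)C3C2)c1` differs from compound 3 by 4-chlorophenyl in place of 3-fluorophenyl on a carbonyl carbon. Going by the values given here, none of the measured steps involves a 4-chlorophenyl group, so they offer no direct guide. All values here lie far from strong inhibition, and compound 4 is expected to remain near the limit, the expected step being an at least 1.2-fold lower number from compound 3 to compound 4 (0.09 log units; that floor lies within the scatter). Compound 4 is estimated at 8000000 nM, within 1500000 nM to 30000000 nM.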

Compound 4, half-maximal inhibitory concentration: 1030000 nM
The estimate for compound 4 lay 7.8-fold (0.89 log units) above the measured number, outside the stated range (below it).
By their numbers in this assay, from the lowest: compound 1; then compounds 4 and 2 (each within the scatter of the next). At a limit, above all of these: compound 3.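

In this assay, the 4-chlorophenyl group gives an at least 9.7-fold lower number from compound 3 to compound 4 (0.98 log units; beyond the scatter), so not every phenyl group carrying one halogen sits at the limit. Against 2-fluorophenyl it gives a 1.8-fold lower number from compound 2 to compound 4 (0.25 log units; within the scatter), so those two groups cannot be told apart, whereas 2-(trifluoromethyl)phenyl still inhibits more strongly, as a 9.2-fold higher number from compound 1 to compound 4 (0.96 log units; beyond the scatter) shows. The figure for compound 3 is a limit of the assay, not a number: the limit of > 10000000 nM in this assay, at which 1 of the 4 values shown sits.

The halogen and its place on the ring change together here, so their contributions cannot be separated. From the compounds shown here alone, how an amine or a methoxy group on the phenyl ring would behave remains open.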